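A few compounds are considered here, and "the series" means these few. Any claim that something is new, unique, unknown or untested is made for them only; others in the source may bear on it.

Among the measured compounds shown here, compound 2 `C=CCn1c(=O)/c(=C\c2ccccc2OC)[nH]c(=O)/c1=C\c1ccccc1OC` is the one compound here with a number: in a functional assay on HeLa cells (Homo sapiens) for cytotoxicity, read by CCK-8 assay, with a stated time of 72 h (on this read-out higher numbers stand for weaker inhibition and lower numbers for stronger inhibition), compound 2 gives 6900 nM. Compound 1 `COc1ccccc1/C=c1/[nH]c(=O)/c(=C\c2cccc(Cl)c2Cl)[nH]c1=O`, which carries a chlorinated ring in place of one methoxyphenyl group and has no allyl, is reported in this assay as "not active" (no number reported), with no number attached. Compound 3 `COc1ccccc1/C=c1/[nH]c(=O)/c(=C\c2ccccc2OC)[nH]c1=O`, which has not yet been measured, differs from compound 2 by hydrogen in place of allyl on an aromatic nitrogen. For the measured compounds named here, no measured pair differs only in this way, so the size of the step is uncertain. Compound 1, the other compound without the allyl group, showed no activity, which points toward compound 3 being weaker than compound 2 rather than stronger, with a fair chance that no number is reported at all. On that basis the expected value of compound 3 in this assay is 20000 nM, within a range from 5000 nM to 100000 nM, and the expected step is a 2.9-fold higher number from compound 2 to compound 3 (0.46 log units; beyond the scatter).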

Compound 3, half-maximal inhibitory concentration: "not active" (no number reported)
Nothing numeric was reported for compound 3, so the estimate cannot be set against anything.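

Among the compounds shown here, compound 3 has no number, so no step from compound 2 to compound 3 can be read. The compounds shown leave open how far the number moves when allyl gives way to hydrogen on the aromatic nitrogen. No measurement shown offers an explanation for the result.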